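Extending the Ring Substituent on an Amide-Type Nitrogen

A few compounds are considered here, and "the series" means these few. Any claim that something is new, unique, unknown or untested is made for them only; others in the source may bear on it.

Compound 1 `CC(=O)Nc1ccc(S(=O)(=O)Oc2ccccc2C(C)C)cc1` gives 21000 nM in a functional assay on M21 cells (Homo sapiens) for antiproliferative activity, read by sulforhodamine B assay, with a stated time of 48 h; on this read-out lower numbers stand for stronger inhibition and higher numbers for weaker inhibition.
Compound 2 `CCNC(=O)Nc1ccc(S(=O)(=O)Oc2ccccc2C(C)C)cc1` gives 4700 nM in this assay.
Compound 3 `CC(C)c1ccccc1OS(=O)(=O)c1ccc(NC(=O)NC2CCCC2)cc1` gives 6100 nM in this assay.

Within this small set compound 3 sits second highest, close to compound 2 and well apart from compound 1. Compound 4 `CC(C)c1ccccc1OS(=O)(=O)c1ccc(NC(=O)NCC2CCCC2)cc1` differs from compound 3 only in one group: cyclopentylmethyl in place of cyclopentyl on an amide-type nitrogen. For the measured compounds named here, of the measured steps, only the one from compound 2 to compound 3 touches the same position, and it changed little: a 1.3-fold higher number from compound 2 to compound 3 (0.11 log units; within the scatter). The other two steps, a 4.5-fold lower number from compound 1 to compound 2 (0.65 log units; beyond the scatter) and a 3.4-fold lower number from compound 1 to compound 3 (0.54 log units; beyond the scatter), concern the carbonyl side and do not speak to this change. With a single comparison at this position, and that one within the scatter, no step beyond the scatter is expected in this assay: a 1.1-fold lower number from compound 3 to compound 4 (0.04 log units; within the scatter). Compound 4 is therefore estimated at 5500 nM, in the range 2500 nM to 12000 nM.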

Compound 4, half-maximal inhibitory concentration: 6600 nM
Compound 4: middle estimate off by 1.2-fold (0.08 log units), on the low side; the range from low to high includes it.
By their numbers in this assay, from the lowest: compounds 2, 3 and 4 (each within the scatter of the next); then compound 1.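

In this assay, cyclopentylmethyl and cyclopentyl on the amide-type nitrogen read alike, with a 1.1-fold higher number from compound 3 to compound 4 (0.03 log units; within the scatter), so the added carbon leaves no mark beyond the scatter. Compound 4 also matches the ethyl-bearing compound 2, with a 1.4-fold higher number from compound 2 to compound 4 (0.15 log units; within the scatter), while the methyl on a carbonyl carbon of compound 1 still stands apart, with a 3.2-fold lower number from compound 1 to compound 4 (0.50 log units; beyond the scatter). No measurement here offers a reason for this flat response.

Still open, going by these compounds, is whether a longer chain ending in cyclopentyl would read the same. On these data alone, it is equally open whether an amine or a carboxylic acid on that chain would shift the number.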